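The compounds below may be only part of what the source reports. "The series", "measured", "known", "first", "only" and "open" are said of these compounds alone.

Measured compounds:
Compound 1, `COc1nc(N)nc2c1c(-c1ccccc1)cn2[C@@H]1O[C@H](CO)[C@@H](O)[C@H]1O`. In a functional assay on CCRF-CEM cells (Homo sapiens), read by MTT assay, with a stated time of 72 h (on this read-out higher numbers stand for weaker inhibition and lower numbers for stronger inhibition), compound 1 gives > 20000 nM, a limit of the assay and not a number.
Compound 2, `C#Cc1cn([C@@H]2O[C@H](CO)[C@@H](O)[C@H]2O)c2nc(N)nc(OC)c12`. In this assay compound 2 gives > 100000 nM, likewise a limit.
Compound 3, `COc1ncnc2c1c(-c1ccccc1)cn2[C@@H]1O[C@H](CO)[C@@H](O)[C@H]1O`. In this assay compound 3 gives > 20000 nM, likewise a limit.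

Compound 1 and compound 2 differ by ethynyl in place of phenyl on an aromatic carbon; the step is a step that the two limits leave unreadable from compound 1 to compound 2. The cores of compound 1 and compound 3 differ by hydrogen in place of amino on an aromatic carbon; that step is a step that the two limits leave unreadable from compound 1 to compound 3. Going by the values given here, two values sit at the limit of > 20000 nM in this assay, at which 2 of the 3 values shown sit, and one at the limit of > 100000 nM in this assay, at which 1 of the 3 values shown sits, so no step among the measured compounds can be read.

Compound 4, `C#Cc1cn([C@@H]2O[C@H](CO)[C@@H](O)[C@H]2O)c2ncnc(OC)c12`, is not yet measured. It differs from compound 3 by ethynyl in place of phenyl on an aromatic carbon. This is the same kind of change as that from compound 1 to compound 2; the surroundings read alike except that the group on the neighbouring ring atom is given once as a 3,4-dihydroxy-5-(hydroxymethyl)oxolan-2-yl group and once only as a group of 9 heavy atoms.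

In this assay the expected step is a step that the limit leaves unreadable from compound 3 to compound 4, set beside a step that the two limits leave unreadable from compound 1 to compound 2, and it rests on compound 2 sitting at the limit of > 100000 nM in this assay, at which 1 of the 3 values shown sits. Compound 4 is expected to give 60000 nM, within 20000 nM to 200000 nM, most likely reported only as a limit.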

Compound 4, half-maximal inhibitory concentration: > 20000 nM
Compound 4: no number, only a limit; the forecaster's own chance of this, stated with the estimate: 90%; the middle value does not contradict the limit.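

In this assay compound 4 gives > 20000 nM, a limit and not a number. No new step can be read, neither between compound 3 and compound 4 nor between compound 2 and compound 4. The compounds shown leave open whether ethynyl in place of phenyl, or hydrogen in place of amino, changes inhibition at all.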